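Swapping a Dimethylpyrazole for a Pyrazine on an Amide Nitrogen

The compounds below may be only part of what the source reports. "The series", "measured", "known", "first", "only" and "open" are said of these compounds alone.

Compound 1 `CCN(Cc1ccco1)C(=O)COc1ccc(C)cc1` gives 489 nM in an assay on HEK293 cells for agonist activity at transient receptor potential cation channel subfamily M member 8 (Homo sapiens), read by fluorescence and calcium flux, with a stated time of 15 min; on this read-out higher numbers stand for an effect only at larger amounts of compound and lower numbers for an effect already at smaller amounts.
Compound 2 `Cc1ccc(OCC(=O)N(Cc2cccs2)c2c(C)n[nH]c2C)cc1` gives 0.3 nM in this assay.

Of the two numbers seen so far, compound 2 has the lowest: its value in this assay sits far below that of compound 1, a gap that is well beyond the usual scatter. Compound 3 `Cc1ccc(OCC(=O)N(Cc2cccs2)c2cnccn2)cc1` keeps everything of compound 2 except one group, and the change is pyrazin-2-yl in place of 3,5-dimethyl-1H-pyrazol-4-yl on an amide-type nitrogen. A five-membered aromatic ring carrying a hydrogen-bond donor is thus traded for a six-membered aromatic ring with none. Among the measured compounds shown here, no measured pair shows this exact swap, so its effect is uncertain. With compound 2 at so low a value, a step upward is expected, from compound 2 to compound 3 of about a 67-fold higher number from compound 2 to compound 3 (1.82 log units; beyond the scatter). Compound 3 is expected to give roughly 20 nM, most likely between 2 nM and 200 nM.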

Compound 3, half-maximal effective concentration: 1240 nM
The estimate for compound 3 lay 62-fold (1.79 log units) below the measured number; measured number outside the range, above it.
By their numbers in this assay, from the lowest: compound 2; then compound 1; then compound 3.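

In this assay, the change on the amide-type nitrogen gives a 4100-fold higher number from compound 2 to compound 3 (3.62 log units; beyond the scatter). The rest of the structure is the same in both compounds, so this whole step belongs to the swap of 3,5-dimethyl-1H-pyrazol-4-yl for pyrazin-2-yl, showing that the group at this position can by itself decide whether the effect appears at very small or much larger amounts of compound. No measurement given here explains why the swap has so large an effect.

The swap alters ring size, the hydrogen-bond donor and acceptor counts and the methyl groups all at once, so this single pair cannot tell which of these changes matters. Still open, as far as these compounds go, is how an unsubstituted pyrazol-4-yl, a plain phenyl or a 3,5-dimethylisoxazol-4-yl would behave on this nitrogen.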